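Series notes: methyl to hydrogen on the aromatic ring

This account rests on a few compounds, and the source may have more. Where it says the series, first, only, none or still open, it means among the compounds named here.

Measured so far:
compound 1 `COC(=O)[C@@H]1COC(/C=C/c2ccc(F)cc2)=N1`: 91.6%
compound 2 `COC(=O)[C@@H]1COC(/C=C/c2ccc(C)cc2)=N1`: 85.1%

In an ADME assay on Vero cells (Chlorocebus sabaeus) for cytotoxicity, read by WST assay, tested at 50 ug/mL (on this read-out lower numbers stand for a stronger effect and higher numbers for a weaker effect at the one concentration tested), compound 1 gives 91.6% and compound 2 gives 85.1%. Going by the values given here, compound 2 holds the lower of the two numbers; the only step is a number 6.5 percentage points lower from compound 1 to compound 2 (within the scatter). Compound 3 `COC(=O)[C@@H]1COC(/C=C/c2ccccc2)=N1` is not yet measured and differs from compound 2 by hydrogen in place of methyl on an aromatic carbon. Among the compounds with values here, the one measured step, methyl in place of fluoro, also on an aromatic carbon, stayed within the scatter, so in this assay nothing beyond the scatter is expected here. The step is estimated as a number 2.9 percentage points higher from compound 2 to compound 3 (within the scatter). Compound 3 is expected at 88%, within 74% to 100%.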

Compound 3, a percentage reported as activity, at one concentration (the size of the read-out at that concentration, not a potency): 68.6%
Compound 3: the middle estimate sits 19.4 percentage points above what was measured; measured number below the stated range.
By their numbers in this assay, from the lowest: compound 3; then compounds 2 and 1 (each within the scatter of the next).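

In this assay this position, on the aromatic ring para to a large group, responds to the change: hydrogen in place of methyl gives a number 16.5 percentage points lower from compound 2 to compound 3 (beyond the scatter), and hydrogen in place of fluoro gives a number 23 percentage points lower from compound 1 to compound 3 (beyond the scatter). Methyl and fluoro stay within the scatter of each other, so among these three compounds the split lies between hydrogen and a substituent, not between the two substituents. Nothing available bears on the reason for this.

On these data alone, it remains open whether a chloro, methoxy or amine group at this place would group with methyl and fluoro or with hydrogen. As far as these compounds go, whether the same split holds on a different core also remains open.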